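A Cyclopropylmethyl Sulfonyl Replaces the Pyridyl Sulfonyl

The compounds below may be only part of what the source reports. "The series", "measured", "known", "first", "only" and "open" are said of these compounds alone.

Compound 1 `O=C(NC[C@]1(CC2CC2)[C@@H]2CN(S(=O)(=O)c3ccccc3F)C[C@@H]21)c1ccc(Cl)cc1Cl`: > 10000 nM
Compound 2 `O=C(NC[C@]1(CC2CC2)[C@@H]2CN(S(=O)(=O)c3cccnc3)C[C@@H]21)c1ccc(Cl)cc1Cl`: 890 nM

Two compounds of this series carry a measured value. In an assay on isolated protein for inhibition of sodium- and chloride-dependent glycine transporter 1 (Homo sapiens) (a lower number here means a stronger inhibitor, a higher number a weaker inhibitor), compound 1 returns only a limit, (the limit of > 10000 nM in this assay, at which 1 of the 2 values shown sits), and not a number. For the measured compounds named here, compound 2 gives 890 nM in this assay, the sole numerical value among the two. Going by the values given here, the single step between them, an at least 11-fold lower number from compound 1 to compound 2 (1.05 log units; beyond the scatter), shows that the group on the sulfonyl sulfur moves the read-out strongly.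

Compound 3 `O=C(NC[C@]1(CC2CC2)[C@@H]2CN(S(=O)(=O)CC3CC3)C[C@@H]21)c1ccc(Cl)cc1Cl` has not been measured. It differs from compound 2 as follows: cyclopropylmethyl in place of pyridin-3-yl on a sulfonyl sulfur. Among the compounds with values here, no measured step exchanges an aromatic group for a saturated one on that sulfur, so the one step available, from a 2-fluorophenyl to a pyridin-3-yl, tells only that the sulfonyl substituent can shift the value by a large amount. The account therefore expects compound 3 to come out weaker than compound 2, with an expected change of a 2.8-fold higher number from compound 2 to compound 3 (0.45 log units; beyond the scatter), though a small loss within the scatter is not ruled out. Compound 3 is estimated at 2500 nM, within an expected range from 500 nM to 12000 nM.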

Compound 3, half-maximal inhibitory concentration: 230 nM
The estimate for compound 3 lay 11-fold (1.04 log units) above the measured number; the measured number lies below the stated range.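

The result shows that an aromatic ring on the sulfonyl sulfur is not needed for activity in this assay: the saturated cyclopropylmethyl group gives a 3.9-fold lower number from compound 2 to compound 3 (0.59 log units; beyond the scatter). The earlier step could be read as a gain tied to the pyridin-3-yl ring and its one hydrogen-bond acceptor, but cyclopropylmethyl, with no hydrogen-bond acceptor, makes compound 3 the strongest of the three, so an acceptor in this group is not required within this set. Against the 2-fluorophenyl group, the same position gives an at least 43-fold lower number from compound 1 to compound 3 (1.63 log units; beyond the scatter), and this size is only a lower bound, since compound 1 returns a limit and not a number: the limit of > 10000 nM in this assay, at which 1 of the 3 values shown sits.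

What the compounds leave open is which feature of cyclopropylmethyl matters, as it differs from pyridin-3-yl in ring size, in aromatic character and in the carbon that separates the ring from the sulfur. An open chain such as n-propyl, a cyclopropyl group set directly on the sulfur, or a dimethylamino group in the same place could separate these features, and how far a saturated group can grow here is also unknown.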